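The compounds below may be only part of what the source reports. "The series", "measured", "known", "first", "only" and "open" are said of these compounds alone.

Compound 3, `CC1CC(=O)N(C(C)C(=O)NCc2ccccc2F)C1=O`, shows the lowest of the three numbers in a functional assay on the whole organism (strain Albino Swiss CD1) with Mus musculus as the target, in the maximal electroshock model (a higher number here means that more compound is needed for the effect, a lower number that less compound is needed), giving 80.5 mg/kg. Compound 2, `CC1CC(=O)N(C(C)C(=O)NCc2cccc(Cl)c2)C1=O`, gives 90.3 mg/kg, and compound 1, `CC1CC(=O)N(C(C)C(=O)NCc2ccccc2)C1=O`, gives 106 mg/kg, both within the scatter of compound 3. Compound 4, `CC1CC(=O)N(C(C)C(=O)NCc2cccc(F)c2)C1=O`, differs from compound 3 by 3-fluorophenyl in place of 2-fluorophenyl on a saturated chain carbon bound to an amide-type nitrogen. Going by the values given here, three measured steps bear on this change: a 1.2-fold lower number from compound 1 to compound 2 (0.07 log units; within the scatter), a 1.3-fold lower number from compound 1 to compound 3 (0.12 log units; within the scatter) and a 1.1-fold lower number from compound 2 to compound 3 (0.05 log units; within the scatter), each an exchange or relocation of a halogen on the aromatic ring, and none beyond the scatter. The step to compound 4 is therefore expected to stay within the scatter as well, a 1.1-fold higher number from compound 3 to compound 4 (0.05 log units; within the scatter). Compound 4 is estimated at 90 mg/kg in this assay, with a range from 60 mg/kg to 135 mg/kg.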

Compound 4, dose for half-maximal effect: 130 mg/kg
Beside the measured number, compound 4's estimate is 1.4-fold (0.16 log units) below it, and the stated range covers the measured number.
By their numbers in this assay, from the lowest: compounds 3, 2, 1 and 4 (each within the scatter of the next).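

In this assay, the relocated fluorine gives a 1.6-fold higher number from compound 3 to compound 4 (0.21 log units; within the scatter), the largest step seen so far on this ring, yet it still does not separate the two compounds. The other new steps, a 1.4-fold higher number from compound 2 to compound 4 (0.16 log units; within the scatter) and a 1.2-fold higher number from compound 1 to compound 4 (0.09 log units; within the scatter), show that neither fluoro in place of chloro nor fluoro in place of hydrogen moves the number beyond the scatter here. On these data alone, whether a methoxy group or an amine on the ring would do so remains open. Nothing at hand gives a reason for these small differences.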